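Swapping the aryl group on the urea of compound 3

The compounds below may be only part of what the source reports. "The series", "measured", "known", "first", "only" and "open" are said of these compounds alone.

Measured so far:
Compound 1 `Cc1cccc(NC(=O)Nn2c(-c3ccccc3)nc3ccccc3c2=O)c1` gives 59% in a functional assay on the whole organism (strain albino) with Mus musculus as the target, at a dose of 100 mg/kg by the intraperitoneal route; on this read-out lower numbers stand for less inhibition and higher numbers for more inhibition at the one dose given (going by the name of the read-out).
Compound 2 `CCc1ccc(NC(=O)Nn2c(CC)nc3ccccc3c2=O)cc1` gives 58% in this assay.
Compound 3 `CCc1nc2ccccc2c(=O)n1NC(=O)Nc1ccc(I)cc1` gives 55% in this assay.

These three compounds share a common core and differ only in the groups attached to it. Compound 3 sits within the usual scatter of both others: its nearest neighbour is compound 2, and even compound 1 lies only a little further away, so none of the three can be called stronger or weaker on this read-out.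

The new compound, compound 4 `CCc1nc2ccccc2c(=O)n1NC(=O)Nc1cccc(C)c1`, has not yet been measured. It differs from compound 3 in one place: 3-methylphenyl in place of 4-iodophenyl on an amide-type nitrogen.

Within the data shown here, only one measured step touches this part of the molecule. Going a number 3 percentage points lower from compound 2 to compound 3 (within the scatter) shows that changing the group on this phenyl ring left the read-out where it was. The 3-methylphenyl group that enters in compound 4 is already carried by compound 1, and compound 1 gives 59%, again within the scatter of compound 3. On this basis the step from compound 3 to compound 4 is expected to be a number 2 percentage points higher from compound 3 to compound 4 (within the scatter), that is, nothing beyond the scatter. For compound 4 the estimated value in this assay is 57%, with a range from 45% to 69%.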

Compound 4, a percentage reported as inhibition, in the whole organism at one dose (the size of the read-out at that dose, not a potency): 53%
Beside the measured number, compound 4's estimate is 4 percentage points above it, and the stated range covers the measured number.
By their numbers in this assay, from the lowest: compounds 4, 3, 2 and 1 (each within the scatter of the next).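

Compound 4 brings a third aryl group onto the urea while the rest of the molecule stays the same, and in this assay the read-out shows a number 2 percentage points lower from compound 3 to compound 4 (within the scatter) and a number 5 percentage points lower from compound 2 to compound 4 (within the scatter), so 4-iodophenyl, 4-ethylphenyl and 3-methylphenyl cannot be told apart at this position. With 3-methylphenyl held fixed, the other variable place can now be read as well: ethyl in place of phenyl on an aromatic carbon gives a number 6 percentage points lower from compound 1 to compound 4 (within the scatter), so this change also stays inside the normal spread of repeat measurements. No available evidence bears on why these swaps leave the read-out in the same range.

The groups on the urea phenyl ring shown here are limited to methyl, ethyl and iodo, so it remains open whether a ring carrying an amine or a carboxylic acid, or a longer chain such as butyl, would give a similar number. Each compound also has a reading at a single dose, which gives the size of the effect at that dose and leaves open whether any of these compounds differ in potency.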